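Amide to urea at the carbonyl in a shared core

The source may hold more compounds than are shown below. What is called first, only, known or untested is meant among the compounds shown, and "the series" means these compounds.

Compound 1 `COc1ccc(-c2cnc3nc(N)nc(N4CCN(C(=O)c5ccccc5)CC4)c3n2)cc1OC` and compound 2 `COc1ccc(-c2cnc3nc(N)nc(NC(C)C)c3n2)cc1OC` share one core and were both tested in a functional assay on cells (T-cell, Homo sapiens) for inhibition; on this read-out higher numbers stand for weaker inhibition and lower numbers for stronger inhibition. In this assay compound 1 gives 400 nM, and compound 2 gives 600 nM; the two numbers lie within the usual scatter of each other, so neither is set apart. Compound 3 `COc1ccc(-c2cnc3nc(N)nc(N4CCN(C(=O)Nc5ccc(C#N)cc5)CC4)c3n2)cc1OC` differs from compound 1 in one place: (4-cyanophenyl)amino in place of phenyl on a carbonyl carbon. Within the data shown here, no measured pair shows this change, so its effect is not known from the data. A step of a 1.1-fold lower number from compound 1 to compound 3 (0.06 log units; within the scatter) is expected, staying within the scatter. Compound 3 is estimated at 350 nM, with a range from 120 nM to 1200 nM.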

Compound 3, half-maximal inhibitory concentration: 74 nM
Beside the measured number, compound 3's estimate is 4.7-fold (0.67 log units) above it; measured number outside the range, below it.
By their numbers in this assay, from the lowest: compound 3; then compounds 1 and 2 (each within the scatter of the next).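

Among these compounds, on a carbonyl carbon whose other neighbour is an amide-type nitrogen in a ring, (4-cyanophenyl)amino in place of phenyl gives a 5.4-fold lower number from compound 1 to compound 3 (0.73 log units; beyond the scatter) in this assay and so provides the first readable step. It shows that this position responds to change, which compounds 1 and 2 could not show. Nothing available bears on the reason for this step. 

On these data alone, the amino link and the nitrile enter together, so their separate shares remain open. Phenylamino on the same carbonyl carbon would separate them, while a carboxylic acid in place of the nitrile would test that end of the group.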